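A few compounds are considered here, and "the series" means these few. Any claim that something is new, unique, unknown or untested is made for them only; others in the source may bear on it.

Of the compounds shown here, three built on one shared core have been measured in an assay on isolated protein for inhibition of bone morphogenetic protein 1 (Homo sapiens); on this read-out higher numbers stand for weaker inhibition and lower numbers for stronger inhibition. Compound 1 `COc1ccc(S(=O)(=O)N(Cc2ccc(Cl)c([N+](=O)[O-])c2)[C@H](C)C(=O)NO)cc1` gives 30 nM, compound 3 `COc1ccc(S(=O)(=O)N(Cc2cccc3ccccc23)[C@H](C)C(=O)NO)cc1` gives 90 nM, and compound 2 `COc1ccc(S(=O)(=O)N(CCn2cccc2)[C@H](C)C(=O)NO)cc1` gives 170 nM. Going by the values given here, of these three numbers, the one for compound 2 is the highest; its gap to compound 3 falls within the usual scatter of repeated measurements, so those two cannot be told apart, whereas its gap to compound 1 lies beyond the scatter. Compound 4 `COc1ccc(S(=O)(=O)N(Cc2cc(F)cc(F)c2)[C@H](C)C(=O)NO)cc1` has not yet been measured in this assay. It arises from compound 2 by one change: 3,5-difluorophenyl in place of (1H-pyrrol-1-yl)methyl on a saturated chain carbon bound to a sulfonamide nitrogen. Among the compounds with values here, no measured pair shows this exact change, so the expectation rests on the wider picture: the other two compounds, compound 1 with 30 nM and compound 3 with 90 nM, both sit at lower numbers than compound 2. The expected step is a 2.8-fold lower number from compound 2 to compound 4 (0.45 log units; beyond the scatter), moderate and toward lower numbers, though it might yet fall within the scatter. For compound 4 the estimate in this assay is 60 nM, with a range from 20 nM to 200 nM.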

Compound 4, half-maximal inhibitory concentration: 140 nM
Estimate against measurement, compound 4: 2.3-fold (0.37 log units) below; low and high end bracket the measured number.
By their numbers in this assay, from the lowest: compound 1; then compounds 3, 4 and 2 (each within the scatter of the next).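

In this assay, 3,5-difluorophenyl takes the place of (1H-pyrrol-1-yl)methyl on a saturated chain carbon bound to a sulfonamide nitrogen, and this gives a 1.2-fold lower number from compound 2 to compound 4 (0.08 log units; within the scatter), so the two groups cannot be told apart here. Going by these compounds alone, this is the first single change measured at this place, and it shows that a five-membered aromatic ring with 1 hetero atom and a six-membered aromatic ring of carbon only, bearing two fluorines, can be exchanged with no reading beyond the scatter. Nothing measured here accounts for this result.

Open, on these data alone, is what the two fluorine atoms contribute on their own, which a plain benzyl group at this place would address. Also open, as far as these compounds go, is whether a chain ending in an amine or a carboxylic acid would move the number beyond the scatter.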